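Halogen swap on two chromanone chalcone isomers

The source may report more compounds than this note shows. Statements on the series, on what has been measured and on what is new or still open speak of the compounds shown alone.

Two pairs of compounds share the same chain and the same triazole, and differ in how the core is joined. Compound 1 `CC1(C)CCc2cc(C(=O)/C=C/c3ccc(OCc4cn(-c5ccc(Cl)cc5)nn4)cc3)c(O)cc2O1` and compound 2 `CC1(C)CCc2cc(C(=O)/C=C/c3ccc(OCc4cn(-c5ccc(Br)cc5)nn4)cc3)c(O)cc2O1` are built on one arrangement of the core; compound 3 `CC1(C)CCc2c(ccc(C(=O)/C=C/c3ccc(OCc4cn(-c5ccc(Cl)cc5)nn4)cc3)c2O)O1` and compound 4 `CC1(C)CCc2c(ccc(C(=O)/C=C/c3ccc(OCc4cn(-c5ccc(Br)cc5)nn4)cc3)c2O)O1` are built on another, in which the same atoms are joined differently. How the two cores differ is not broken down here.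

In a functional assay on A549 cells (Homo sapiens) for antiproliferative activity, read by MTT assay (on this read-out lower numbers stand for stronger inhibition and higher numbers for weaker inhibition), compound 1 gives 75500 nM. Compound 2 gives 80000 nM. The change between them is bromo in place of chloro on an aromatic carbon and it produced a 1.1-fold higher number from compound 1 to compound 2 (0.03 log units; within the scatter). Compound 3 gives "not active" (no number reported); no number was reported for it in this assay.

Compound 4 carries the same change relative to compound 3, namely (bromo in place of chloro on an aromatic carbon). For the measured compounds named here, the only guide to its size is the earlier pair, where the step from chloro to bromo stayed within the usual scatter, so the expectation is that compound 4 should sit close to where compound 3 sits, and since compound 3 gave no number, compound 4 is expected most likely to give no number either, or a very weak one. Her estimate for compound 4 in this assay is 100000 nM, with a range from 50000 nM to 250000 nM, and a considerable chance that only a limit is reported.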

Compound 4, half-maximal inhibitory concentration: 129000 nM
Beside the measured number, compound 4's estimate is 1.3-fold (0.11 log units) below it, within the range that was stated.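

In this assay compound 3 has no number and compound 4 gives 129000 nM, so the step from chloro to bromo between these two compounds cannot be read. The compounds shown leave open whether this swap has the same size on the core of compound 3 as on the core of compound 1. Nothing available here bears on the reason for these results.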